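This account rests on a few compounds, and the source may have more. Where it says the series, first, only, none or still open, it means among the compounds named here.

Compound 1, `CCc1ccc(Nc2nccc(-c3ccncc3)n2)cc1`: 7700 nM
Compound 2, `CCc1ccc(Nc2nccc(-c3cc(C)oc3C)n2)cc1`: 19200 nM

Both were tested in a functional assay for inhibition, with Homo sapiens as the target; a higher number here means a weaker inhibitor, a lower number a stronger inhibitor. Compound 1 stands at the lowest of the two numbers, so it is the stronger inhibitor of the pair. Going by the values given here, the only measured step, a 2.5-fold higher number from compound 1 to compound 2 (0.40 log units; beyond the scatter), comes from putting 2,5-dimethylfuran-3-yl in place of pyridin-4-yl on an aromatic carbon, a modest change beyond the scatter.

Compound 3, `c1ccc(Nc2nccc(-c3ccncc3)n2)cc1`, has not yet been measured in this assay. It differs from compound 1 by hydrogen in place of ethyl on an aromatic carbon. Among the compounds with values here, the measured step concerns a different part of the molecule, so no measured step bears directly on removing the ethyl; the change is small, two carbon atoms leaving a ring edge. The expectation is therefore a step of a 1.4-fold higher number from compound 1 to compound 3 (0.15 log units; within the scatter), likely within or just beyond the scatter, with a slight loss of potency as the more probable direction. Compound 3 is estimated at 11000 nM, with a range from 4500 nM to 28000 nM.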

Compound 3, half-maximal inhibitory concentration: 900 nM
Compound 3: the middle estimate sits 12-fold (1.09 log units) above what was measured; the whole stated range lies above it.
By their numbers in this assay, from the lowest: compound 3; then compound 1; then compound 2.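

This position matters far more than the small size of the change would suggest. On the aromatic carbon para to a large group, hydrogen in place of ethyl gives an 8.6-fold lower number from compound 1 to compound 3 (0.93 log units; beyond the scatter) in this assay, so compound 3 is the stronger inhibitor, and this step is larger than the one at the other end of the molecule, a 2.5-fold higher number from compound 1 to compound 2 (0.40 log units; beyond the scatter). Nothing measured here gives a reason for the gain on losing the ethyl.

From the compounds shown here alone, with only hydrogen and ethyl to compare at this position, it remains open whether a methyl, a methoxy group, a chlorine atom or an amine would behave like hydrogen or like ethyl. Going by these compounds, it is also open whether removing the ethyl brings a similar gain when 2,5-dimethylfuran-3-yl stands in place of pyridin-4-yl.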